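The source may hold more compounds than are shown below. What is called first, only, known or untested is meant among the compounds shown, and "the series" means these compounds.

Measured so far in an ADME assay on HOS cells (Homo sapiens) for cytotoxicity; a lower number here means that less compound is tolerated, a higher number that more compound is tolerated:
compound 1 `CN1CCN(c2cccc3nc(CN(C)[C@H]4CCCc5cccnc54)cn23)CC1`: 4500 nM
compound 2 `CN1CCC(N(C)c2cccc3nc(CN(C)[C@H]4CCCc5cccnc54)cn23)C1`: 10800 nM
compound 3 `CN(Cc1cn2c(N3CCC(N)CC3)cccc2n1)[C@H]1CCCc2cccnc21`: 6300 nM

Compound 1 gives the lowest of the three numbers; compound 3 sits nearest, a 1.4-fold higher number from compound 1 to compound 3 (0.15 log units; within the scatter), and compound 2 furthest, a 2.4-fold higher number from compound 1 to compound 2 (0.38 log units; beyond the scatter). Compound 4 `CN1CCN(c2cccc3nc(CN(CC4CC4)[C@H]4CCCc5cccnc54)cn23)CC1` is the next change from compound 1: cyclopropyl in place of hydrogen on a saturated chain carbon bound to an amine nitrogen. All three measured steps, including a 1.7-fold lower number from compound 2 to compound 3 (0.23 log units; within the scatter), exchange the group on an aromatic carbon of the shared core and leave the amine side untouched, so none bears directly on this change, and their spread is modest in any case. With nothing at the amine to draw on, compound 4 is expected to stay near the level of its parent: the expected step is no change at the digits printed from compound 1 to compound 4 (within the scatter), not beyond the scatter. Compound 4 is estimated at 4500 nM in this assay, with a range from 2000 nM to 10000 nM.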

Compound 4, half-maximal cytotoxic concentration: 8000 nM
For compound 4 the middle estimate is 1.8-fold (0.25 log units) below the measured one; low and high end bracket the measured number.
By their numbers in this assay, from the lowest: compounds 1, 3, 4 and 2 (each within the scatter of the next, the first and the last beyond it).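

In this assay, among the compounds shown here, the amine side of the series is touched for the first time, and methyl to cyclopropylmethyl gives a 1.8-fold higher number from compound 1 to compound 4 (0.25 log units; within the scatter) on the shared core. The earlier steps shown here all lay on an aromatic carbon, whereas this one shows that cyclopropyl in place of hydrogen at this saturated chain carbon leaves the number within the scatter of its parent. Nothing available explains the size of this step.

Open, on these data alone, is whether a longer chain, such as n-butyl, or a chain ending in a primary amine or carboxylic acid would stay as close. Also open, as far as these compounds go, is how cyclopropylmethyl reads with 4-aminopiperidin-1-yl or methyl(1-methylpyrrolidin-3-yl)amino on the aromatic carbon.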